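A few compounds are considered here, and "the series" means these few. Any claim that something is new, unique, unknown or untested is made for them only; others in the source may bear on it.

In a functional assay on A549 cells (Homo sapiens) for antiproliferative activity, read by MTT assay, with a stated time of 48 h (a higher number here means a weaker inhibitor, a lower number a stronger inhibitor), compound 3 `CN1CCN(Cc2ccc3c(c2O)-c2ccc(cc2O)CCc2ccc(O)c(c2)Oc2ccc(cc2)CC3)CC1` gives 5590 nM. Two close relatives share its core: compound 1 `CCN(CC)Cc1ccc2c(c1O)-c1ccc(cc1O)CCc1ccc(O)c(c1)Oc1ccc(cc1)CC2` gives 5740 nM, and compound 2 `Oc1ccc2cc1Oc1ccc(cc1)CCc1ccc(CN3CCCCC3)c(O)c1-c1ccc(cc1O)CC2` gives 7120 nM. These three numbers lie within the scatter of one another, so compound 3 stands level with the others and cannot be ranked above them.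

Compound 4 `CCCCN(CCCC)Cc1ccc2c(c1O)-c1ccc(cc1O)CCc1ccc(O)c(c1)Oc1ccc(cc1)CC2` keeps the same core but carries dibutylamino in place of 4-methylpiperazin-1-yl on a saturated chain carbon bound to an aromatic carbon.

Within the data shown here, three measured steps bear on this change, and each swaps the amine at that same place. The first is a 1.2-fold higher number from compound 1 to compound 2 (0.09 log units; within the scatter), the second is a 1.0-fold lower number from compound 1 to compound 3 (0.01 log units; within the scatter), and the third is a 1.3-fold lower number from compound 2 to compound 3 (0.11 log units; within the scatter). The second matters most, since compound 1 also carries an open-chain amine, diethylamino, and its step to the ring-bearing compound 3 is the smallest of the three. Among the measured compounds shown here, none of the measured compounds carries dibutylamino, so the longer chains remain untested, and the expected range has to stay wide.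

With all three steps inside the scatter, no step beyond the scatter is expected here, and the estimate is a 1.0-fold lower number from compound 3 to compound 4 (0.01 log units; within the scatter). For compound 4 the estimated value is 5500 nM, with an expected range from 3000 nM to 10000 nM.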

Compound 4, half-maximal inhibitory concentration: > 20000 nM
Compound 4 was reported as a limit (the forecaster's own chance of this, stated with the estimate: 3%); at least 3.6-fold (0.56 log units) between middle value and limit.
By their numbers in this assay, from the lowest: compounds 3, 1 and 2 (each within the scatter of the next). At a limit, above all of these: compound 4.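

In this assay compound 4 gives no number, only a limit: the limit of > 20000 nM in this assay, at which 1 of the 4 values shown sits.

Even read against that limit, the group on a saturated chain carbon bound to an aromatic carbon now makes a difference, with dibutylamino giving an at least 3.5-fold higher number from compound 3 to compound 4 (0.55 log units; beyond the scatter), an at least 2.8-fold higher number from compound 2 to compound 4 (0.44 log units; beyond the scatter) and an at least 3.4-fold higher number from compound 1 to compound 4 (0.54 log units; beyond the scatter). The earlier compounds shown here could not show this, since diethylamino, piperidin-1-yl and 4-methylpiperazin-1-yl all stayed within the scatter of one another, and the step from compound 1 adds that an open-chain amine at this place is not enough to separate a compound from the others, since diethylamino and dibutylamino are both open-chain amines yet only dibutylamino stands apart.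

From the compounds shown here alone, since compound 4 is known only as a limit, the full size of these steps remains open. Also open, going by these compounds, is where the loss sets in as the chains grow, which dipropylamino, with chains longer than ethyl and shorter than butyl, could help to settle, and whether a larger ring amine such as azepan-1-yl stays level with the piperidin-1-yl of compound 2.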